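The source may report more compounds than this note shows. Statements on the series, on what has been measured and on what is new or still open speak of the compounds shown alone.

In an ADME assay on HEp-2 cells (Homo sapiens) for cytotoxicity (a higher number here means that more compound is tolerated, a lower number that less compound is tolerated), compound 1 `CC(C)CCn1c(CN2C(=O)C(CC(=O)O)c3ccccc32)nc2ccccc21` gives 16500 nM and compound 2 `CC(C)CCn1c(CN2C(=O)C(CC(=O)NCc3ccccc3)c3ccccc32)nc2ccccc21` gives 720 nM as the lower of the two numbers. Compound 3 `N#CCCCCn1c(CN2C(=O)CS(=O)(=O)c3ccccc32)nc2ccccc21` gives > 270000 nM as a limit of the assay and not a number. Compound 4 `CC(C)CCn1c(CN2C(=O)C(CC(=O)N(C)C)c3ccccc32)nc2ccccc21` differs from compound 2 by dimethylamino in place of benzylamino on a carbonyl carbon with the core unchanged. Among the compounds with values here, the one measured step at this place is a 23-fold lower number from compound 1 to compound 2 (1.36 log units; beyond the scatter) with benzylamino in place of hydroxy. Compound 4 loses that benzylamino without regaining hydroxy, so only part of that step is expected to reverse in this assay as well. The expected change is a 4.9-fold higher number from compound 2 to compound 4 (0.69 log units; beyond the scatter) toward a higher number. For compound 4 the estimate is 3500 nM with an expected range from 1000 nM to 12000 nM in this assay.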

Compound 4, half-maximal cytotoxic concentration: 4670 nM
Compound 4: the middle estimate sits 1.3-fold (0.13 log units) below what was measured, and the stated range covers the measured number.
By their numbers in this assay, from the lowest: compound 2; then compound 4; then compound 1. At a limit, above all of these: compound 3.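

In this assay, the carbonyl carbon now carries three different groups, and the step is not simply a matter of losing hydroxy: dimethylamino gives a 3.5-fold lower number from compound 1 to compound 4 (0.55 log units; beyond the scatter). Exchanging benzylamino for dimethylamino gives a 6.5-fold higher number from compound 2 to compound 4 (0.81 log units; beyond the scatter), so the number depends on what the amide nitrogen carries and not only on the presence of an amide. Nothing measured here accounts for either step.

Dimethylamino removes the benzyl ring and the amide hydrogen together, leaving their separate contributions open. A methylamino or a phenethylamino group at this carbonyl carbon would help separate them.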